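Trading trifluoromethyl for 1-methyl-1H-pyrazol-4-yl in compound 2

The compounds below may be only part of what the source reports. "The series", "measured", "known", "first", "only" and "open" are said of these compounds alone.

Three compounds that share one core and differ in a single aromatic group have been tested in a functional assay on HeLa cells (Homo sapiens) for inhibition, read by CCK-8 assay, with a stated time of 48 h; on this read-out higher numbers stand for weaker inhibition and lower numbers for stronger inhibition. Compound 1 (`COc1cc(-c2ccnc3cc(-c4cccc(C#N)c4)nn23)cc(OC)c1OC`) gives > 10000 nM, which is a limit of the assay and not a number. Compound 2 (`COc1cc(-c2ccnc3cc(-c4ccc(C(F)(F)F)cc4)nn23)cc(OC)c1OC`) gives 1840 nM, the higher of the two actual numbers. Compound 3 (`COc1cc(-c2ccnc3cc(-c4ccc5ccn(C)c5c4)nn23)cc(OC)c1OC`) gives 187 nM. Between these two numbers lies a 9.8-fold lower number from compound 2 to compound 3 (0.99 log units; beyond the scatter).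

The next compound is compound 4 (`COc1cc(-c2ccnc3cc(-c4ccc(-c5cnn(C)c5)cc4)nn23)cc(OC)c1OC`), which differs from compound 2 at one place: 1-methyl-1H-pyrazol-4-yl in place of trifluoromethyl on an aromatic carbon. The new group stands on an aromatic carbon, para to a large group. Going by the values given here, no measured step makes this exact change. The nearest evidence comes from exchanging the whole aromatic group, which gave an at least 5.4-fold lower number from compound 1 to compound 2 (0.73 log units; beyond the scatter) and an at least 53-fold lower number from compound 1 to compound 3 (1.72 log units; beyond the scatter), so the read-out clearly responds to changes in this part of the molecule. The only measured replacement of the 4-(trifluoromethyl)phenyl group, a 9.8-fold lower number from compound 2 to compound 3 (0.99 log units; beyond the scatter), went towards stronger inhibition, so a smaller move in that direction is expected, with wide uncertainty. The expected change is a 2.6-fold lower number from compound 2 to compound 4 (0.42 log units; beyond the scatter). Compound 4 is estimated at 700 nM, with an expected range from 150 nM to 4000 nM.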

Compound 4, half-maximal inhibitory concentration: 1830 nM
For compound 4 the middle estimate is 2.6-fold (0.42 log units) below the measured one; low and high end bracket the measured number.
By their numbers in this assay, from the lowest: compound 3; then compounds 4 and 2 (each within the scatter of the next). At a limit, above all of these: compound 1.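

In this assay, putting 1-methyl-1H-pyrazol-4-yl in place of trifluoromethyl on this aromatic carbon gives a 1.0-fold lower number from compound 2 to compound 4 (0.00 log units; within the scatter). The earlier compounds shown here showed that exchanging the whole aromatic group can move the read-out, whereas this step shows that a substantial change at this one place, para to a large group, can leave it unmoved: a group with no ring and no hydrogen-bond acceptors leaves, and one with a five-membered aromatic ring and hydrogen-bond acceptors enters, with no difference beyond the scatter. The stronger inhibition seen in a 9.8-fold lower number from compound 2 to compound 3 (0.99 log units; beyond the scatter) came with a replacement of the whole 4-(trifluoromethyl)phenyl group, and it does not carry over to this single exchange.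

Going by these compounds alone, only two groups at this place can be compared here, so it remains open whether an amine, a carboxylic acid or a longer chain on the same aromatic carbon would shift the number in either direction. Compound 1 also remains a limit and not a number, which leaves the true size of its steps open: the limit of > 10000 nM in this assay, at which 1 of the 4 values shown sits.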